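The compounds below may be only part of what the source reports. "The series", "measured", "known", "first", "only" and "open" are said of these compounds alone.

Measured in a functional assay on MDA-MB-231 cells (Homo sapiens) for cytotoxicity, read by sulforhodamine B assay, with a stated time of 72 h; on this read-out lower numbers stand for stronger inhibition of growth and higher numbers for weaker inhibition of growth:
- compound 1 `O=C(Nc1ccccc1C(F)(F)F)C1CCc2ccccc2N1C(=O)c1cccc(Cl)c1`: 288 nM
- compound 2 `O=C(Nc1cc(C(F)(F)F)cc(C(F)(F)F)c1)C1CCc2ccccc2N1C(=O)c1ccc(Cl)cc1`: 2000 nM
- compound 3 `CC(=O)N1c2ccccc2CCC1C(=O)Nc1ccccc1C(F)(F)F`: > 80000 nM (a limit, not a number)

Of the two numeric values, the higher belongs to compound 2, at 2000 nM. The next structure is compound 4 `O=C(Nc1cc(C(F)(F)F)cc(C(F)(F)F)c1)C1CCc2ccccc2N1C(=O)c1cccc(Cl)c1`, with the change 3-chlorophenyl in place of 4-chlorophenyl on a carbonyl carbon.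

Among the measured compounds shown here, the only measured step at this place is an at least 270-fold higher number from compound 1 to compound 3 (2.44 log units; beyond the scatter). That step is large, but it replaces the 3-chlorophenyl with methyl and so does not compare the two chlorophenyl groups. For the measured compounds named here, no measured pair isolates the present change, so only a small step is expected in this assay, possibly within the scatter. A slight lean towards a lower number is expected, as compound 1, which also carries the 3-chlorophenyl, gives 288 nM. The expected step is a 1.7-fold lower number from compound 2 to compound 4 (0.22 log units; within the scatter). For compound 4 the estimated value is 1200 nM, with an expected range from 350 nM to 4000 nM.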

Compound 4, concentration for 50% growth inhibition: 1190 nM
For compound 4 the middle estimate is 1.0-fold (0.00 log units) above the measured one; the range from low to high includes it.
By their numbers in this assay, from the lowest: compound 1; then compounds 4 and 2 (each within the scatter of the next). At a limit, above all of these: compound 3.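

Among the compounds shown here, this is the first pair to isolate the two chlorophenyl groups on the carbonyl carbon, with the rest of the structure unchanged. In this assay the exchange of 4-chlorophenyl for 3-chlorophenyl gives a 1.7-fold lower number from compound 2 to compound 4 (0.23 log units; within the scatter), so this one pair does not separate the two groups, and the place of the chlorine on the ring carries no readable weight here. Nothing measured here bears on why the two groups read alike.

Still open is whether the same holds on the amide side carried by compound 1, where no such pair is shown. Also open, on these data alone, is how this position responds to a phenyl without chlorine, a methoxy or carboxylic acid on that ring, or a longer chain in place of the ring.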